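A few compounds are considered here, and "the series" means these few. Any claim that something is new, unique, unknown or untested is made for them only; others in the source may bear on it.

Measured so far:
Compound 1 `COC(=O)c1ccc2ccc(C(=O)c3ccccc3)c-2cc1` gives in a physicochemical assay for solubility, with a stated time of 24 h, at pH 4.5 (a higher number here means a more soluble compound, a lower number a less soluble compound), a reading of < 1 ug/mL, which is a limit of the assay and not a number.
Compound 2 `COC(=O)c1ccc2c(C(=O)c3ccccc3)cc(C(=O)c3ccccc3)c-2cc1` gives in this assay a reading of < 1 ug/mL, which is again a limit of the assay.

Among the compounds with values here, compound 1 therefore stands at no fixed number in this assay: only a limit is known for it, and the one further value shown is likewise a limit. The step from compound 1 to compound 2, a step that the two limits leave unreadable from compound 1 to compound 2, cannot be read because both values sit at the limit of < 1 ug/mL in this assay, at which 2 of the 2 values shown sit.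

Compound 3 `O=C(NCc1cccnc1)c1ccc2ccc(C(=O)c3ccccc3)c-2cc1` differs from compound 1 by ((pyridin-3-yl)methyl)amino in place of methoxy on a carbonyl carbon. No measured step involves this change; the only step shown concerns a benzoyl in place of hydrogen on an aromatic carbon and is itself unreadable, so the measured steps give neither a size nor a direction for the step in this assay. The step of an at least 5.0-fold higher number from compound 1 to compound 3 (0.69 log units; beyond the scatter) is thus an estimate resting on the structural change alone. Compound 3 is expected to give about 5 ug/mL, within a range from 0.5 ug/mL to 50 ug/mL, with a real chance that the assay again reports only a limit.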

Compound 3, solubility: < 1 ug/mL
Compound 3 was reported as a limit; the forecaster's own chance of this, stated with the estimate: 35%; middle value at least 5.0-fold (0.69 log units) from the limit.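

Compound 3 also returned only a limit of the assay and not a number, so no step between compound 1 and compound 3 can be read in this assay: the limit of < 1 ug/mL in this assay, at which 3 of the 3 values shown sit.

The compounds shown leave open where each true value lies relative to that limit, and whether ((pyridin-3-yl)methyl)amino in place of methoxy on a carbonyl carbon changes the reading at all.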